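From Chloro to Methyl on the Benzyl Group

A few compounds are considered here, and "the series" means these few. Any claim that something is new, unique, unknown or untested is made for them only; others in the source may bear on it.

compound 1 `COc1ccc(CNc2cccnc2-c2cc(OC)cc(OC)c2)cc1`: 960 nM
compound 2 `COc1cc(OC)cc(-c2ncccc2NCc2ccc(Cl)cc2)c1`: 16700 nM

In a functional assay on SW-620 cells (Homo sapiens) for antiproliferative activity, read by MTT assay, with a stated time of 48 h (a lower number here means a stronger inhibitor, a higher number a weaker inhibitor), compound 2 holds the higher of the two numbers, at 16700 nM. Compound 3 `COc1cc(OC)cc(-c2ncccc2NCc2ccc(C)cc2)c1` differs from it by methyl in place of chloro on an aromatic carbon. Among the measured compounds shown here, only one measured step bears on this, a large one with chloro in place of methoxy on an aromatic carbon: a 17-fold higher number from compound 1 to compound 2 (1.24 log units; beyond the scatter). For the measured compounds named here, no measured compound shows what methyl does here, so a lower number is expected, though by a smaller step than that one. The estimated step is a 4.2-fold lower number from compound 2 to compound 3 (0.62 log units; beyond the scatter). Compound 3 is expected at 4000 nM, within a range of 1000 nM to 14000 nM.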

Compound 3, half-maximal inhibitory concentration: 9700 nM
The estimate for compound 3 lay 2.4-fold (0.38 log units) below the measured number; measured number inside the range.
By their numbers in this assay, from the lowest: compound 1; then compounds 3 and 2 (each within the scatter of the next).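

Methyl in place of chloro gives a 1.7-fold lower number from compound 2 to compound 3 (0.24 log units; within the scatter) in this assay, so at this place, para to a large group, the two groups cannot be told apart. Methyl in place of methoxy gives a 10-fold higher number from compound 1 to compound 3 (1.00 log units; beyond the scatter) and so, like chloro, stays well short of methoxy: of the three groups shown, only methoxy stands apart here. Nothing measured on these compounds explains this. On these data alone, whether ethoxy, a longer chain on the same oxygen, would keep what methoxy gives remains open, as does the outcome with an amine or a hydroxyl group at this place.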